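Sulfonamide piperidines: methyl to isopropyl on the outer ring

The source may hold more compounds than are shown below. What is called first, only, known or untested is meant among the compounds shown, and "the series" means these compounds.

Measured compounds:
compound 1, `Cc1c(C)c(S(=O)(=O)N2CCC(N3CCC(C)CC3)CC2)c(C)c2c1OC(C)(C)C2`, in a functional assay on HT-29 cells (Homo sapiens) for antiproliferative activity, read by CellTiter-Glo, with a stated time of 72 h (a higher number here means a weaker inhibitor, a lower number a stronger inhibitor), compound 1 gives 0.8 nM
compound 2, `COc1ccc(Br)cc1S(=O)(=O)N1CCC(N2CCC(C)CC2)CC1`, in this assay compound 2 gives 2 nM
compound 3, `Cc1cc(C)c(S(=O)(=O)N2CCC(N3CCC(C)CC3)CC2)c(C)c1`, in this assay compound 3 gives 0.9 nM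

Compound 3 stands second highest of the three numbers. Its value and that of compound 1 lie within the usual scatter of each other, so no order between them is claimed; compound 2 gives a higher number, and that gap lies beyond the scatter.

Compound 4, `Cc1cc(C)c(S(=O)(=O)N2CCC(N3CCC(C(C)C)CC3)CC2)c(C)c1`, differs from compound 3 in one place: isopropyl in place of methyl on a saturated ring carbon. Among the compounds with values here, no measured pair in the set isolates this kind of change, so there is no step to lean on. The step of a 1.7-fold higher number from compound 3 to compound 4 (0.22 log units; within the scatter) is expected to be small, most likely within the scatter, with no direction favoured. Compound 4 is therefore expected to give 1.5 nM in this assay, estimated between 0.5 nM and 5 nM.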

Compound 4, half-maximal inhibitory concentration: 0.2 nM
Estimate against measurement, compound 4: 7.5-fold (0.88 log units) above, and the stated range ends above it.
By their numbers in this assay, from the lowest: compound 4; then compounds 1 and 3 (each within the scatter of the next); then compound 2.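

In this assay, going from 4-methylpiperidin-1-yl to 4-isopropylpiperidin-1-yl gives a 4.5-fold lower number from compound 3 to compound 4 (0.65 log units; beyond the scatter), so this saturated ring carbon responds to the size of its alkyl group, and the larger group does not cost activity. The earlier compounds shown here all carry methyl here, so they could not show this. Nothing available explains the step.

From the compounds shown here alone, whether a longer chain such as n-butyl, an amine or a carboxylic acid on this ring carbon would move the number further stays open. So does whether isopropyl gives a similar step on the cores of compound 1 and compound 2.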